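A few compounds are considered here, and "the series" means these few. Any claim that something is new, unique, unknown or untested is made for them only; others in the source may bear on it.

Measured compounds in a functional assay on HeLa cells (Homo sapiens) for inhibition, read by MTT assay, with a stated time of 72 h; a lower number here means a stronger inhibitor, a higher number a weaker inhibitor:
Compound 1, `CC(C)c1cc(C(C)C)c(C(=O)/C=C/C(=O)O)c(C(C)C)c1`: 6100 nM
Compound 2, `CC(C)(C)c1ccc(C(=O)/C=C/C(=O)O)cc1`: 5100 nM
Compound 3, `COc1ccc(C(=O)/C=C/C(=O)O)c(OC)c1OC`: 96200 nM

Compound 2 gives the lowest of the three numbers in this assay. Compound 1 sits nearest, within the scatter, so no order between compound 2 and compound 1 is claimed; compound 3 lies furthest off, well beyond the scatter. Compound 4, `O=C(O)/C=C/C(=O)c1ccc(F)cc1`, is not yet measured. Relative to compound 2 it carries fluoro in place of tert-butyl on an aromatic carbon. For the measured compounds named here, no measured pair isolates this exchange, so its effect is unknown from the series. A small shift toward a higher number in this assay is expected for compound 4, possibly just beyond the scatter, given the weaker showing of compound 3 once the para group is altered; the expected step is a 2.2-fold higher number from compound 2 to compound 4 (0.33 log units; beyond the scatter). Compound 4 is estimated at 11000 nM, within 3500 nM to 40000 nM.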

Compound 4, half-maximal inhibitory concentration: 28400 nM
The estimate for compound 4 lay 2.6-fold (0.41 log units) below the measured number, within the range that was stated.
By their numbers in this assay, from the lowest: compounds 2 and 1 (each within the scatter of the next); then compound 4; then compound 3.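

In this assay, for the compounds shown here, the exchange of tert-butyl for fluoro, para to a group of 7 heavy atoms, gives a 5.6-fold higher number from compound 2 to compound 4 (0.75 log units; beyond the scatter) and is the first single-place reading, showing that this position is sensitive to the group it carries. With one exchange, the drop from 4 heavy atoms to 1 cannot be separated from the change of element. Nothing available explains the step.

As far as these compounds go, whether an amine, a methoxy group or a longer chain at this position would stay near compound 2 or fall toward compound 4 remains open. A single pair sets no trend.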